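A few compounds are considered here, and "the series" means these few. Any claim that something is new, unique, unknown or untested is made for them only; others in the source may bear on it.

Measured so far:
- compound 2, `CCCCNc1nc(N)nc(C)c1CCc1ccccc1`: 1190 nM
- compound 1, `CCCCNc1nc(N)nc(C)c1CCCCc1ccccc1`: 857 nM

The account follows the step from compound 2 to compound 3. Of the compounds shown here, two have been measured in an assay on HEK293 cells for agonist activity at Toll-like receptor 8 (Homo sapiens), read by spectrophotometry; a higher number here means that more compound is needed for the effect, a lower number that less compound is needed. Compound 1, `CCCCNc1nc(N)nc(C)c1CCCCc1ccccc1`, gives 857 nM in this assay. Compound 2, `CCCCNc1nc(N)nc(C)c1CCc1ccccc1`, gives 1190 nM in this assay. Compound 2 carries the higher of the two numbers, but its gap to compound 1 lies within the scatter, so the two values are not told apart.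

Compound 3, `CCCCNc1nc(N)nc(C)c1CCCC(C)(C)O`, has not yet been measured. Against compound 2 its structure differs in one place: 2-hydroxy-2-methylpropyl in place of phenyl on a saturated chain carbon, two bonds along the chain from an aromatic carbon. Among the measured compounds shown here, no step between measured compounds covers a change of this kind, so the only footing is the pair of values already in hand.

The step from compound 2 to compound 3 is expected to be small and toward a higher number, as a 1.3-fold higher number from compound 2 to compound 3 (0.10 log units; within the scatter), though it may well stay within the scatter. For compound 3 in this assay a value of 1500 nM is estimated, with a range from 500 nM to 4500 nM.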

Compound 3, half-maximal effective concentration: 1220 nM
Compound 3: the middle estimate sits 1.2-fold (0.09 log units) above what was measured; measured number inside the range.
By their numbers in this assay, from the lowest: compounds 1, 2 and 3 (each within the scatter of the next).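

Putting 2-hydroxy-2-methylpropyl in place of phenyl on this saturated chain carbon gives a 1.0-fold higher number from compound 2 to compound 3 (0.01 log units; within the scatter) in this assay and so leaves the value within the scatter, even though an aromatic ring of carbon only gives way to a group with no ring, 1 hydrogen-bond donor and 1 hydrogen-bond acceptor. Compound 1 and compound 2 both carry phenyl and could not show this, whereas the new result shows that, among these three compounds, the phenyl ring is not needed for a value in this range, and the comparison with the longer chain agrees, with 1-hydroxy-1-methylethyl in place of benzyl giving a 1.4-fold higher number from compound 1 to compound 3 (0.15 log units; within the scatter) as the step. Nothing available explains why so different a group leaves the number where it was.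

The compounds shown leave open whether an amine or a carboxylic acid in place of the 2-hydroxy-2-methylpropyl group would give a number beyond the scatter. They also leave open whether the hydroxyl group or the two methyl groups matter on their own, which a simple 2-hydroxyethyl group or a plain isobutyl group in the same place would address.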